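Moving from pyrrolyl to dimethylphenyl in a benzylthio enone

The source may hold more compounds than are shown below. What is called first, only, known or untested is meant among the compounds shown, and "the series" means these compounds.

Compound 3 `O=C(/C(=C\c1ccc[nH]1)SCc1ccc(Cl)cc1)c1ccc(Cl)cc1` gives 10000 nM in a functional assay on DU-145 cells (Homo sapiens) for inhibition, read by trypan blue exclusion, with a stated time of 96 h (a higher number here means a weaker inhibitor of growth, a lower number a stronger inhibitor of growth), level with compound 2 `Cc1ccc(S/C(=C/c2ccc[nH]2)C(=O)c2ccc(Cl)cc2)cc1` at 10000 nM and a greater number than compound 1 `O=C(/C(=C\c1ccc(F)c([N+](=O)[O-])c1)SCc1ccc(F)cc1)c1ccc(F)cc1` at 1000 nM. Compound 4 `Cc1ccc(C)c(/C=C(/SCc2ccc(Cl)cc2)C(=O)c2ccc(Cl)cc2)c1` is yet to be measured; it differs from compound 3 by 2,5-dimethylphenyl in place of 1H-pyrrol-2-yl on a double-bonded chain carbon bound to a double-bonded chain carbon. Among the compounds with values here, the single measured step, no change at the digits printed from compound 2 to compound 3 (within the scatter), concerns the sulfur substituent and does not bear on the arylidene position; compound 1 carries an aryl group here but also differs at the halogens, so only its smaller value hints at the direction. The step of a 3.3-fold lower number from compound 3 to compound 4 (0.52 log units; beyond the scatter) is therefore expected to be a modest decrease, and compound 4 is estimated at 3000 nM, between 1000 nM and 15000 nM.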

Compound 4, concentration for 50% growth inhibition: 10000 nM
Compound 4: the middle estimate sits 3.3-fold (0.52 log units) below what was measured, within the range that was stated.
By their numbers in this assay, from the lowest: compound 1; then compounds 2, 3 and 4 (each within the scatter of the next).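

In this assay, within the data shown here, 2,5-dimethylphenyl on this double-bonded chain carbon gives no change at the digits printed from compound 3 to compound 4 (within the scatter), the first reading at this position. Here, exchanging the 1H-pyrrol-2-yl ring and its hydrogen-bond donor for an all-carbon six-membered aromatic ring leaves the number unmoved. No available evidence accounts for this outcome.

The compounds shown leave open which of its several differences sets compound 1 apart from the others. They also leave open whether a carboxylic acid or a dimethylamino group on the aryl ring at this position would shift the number.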